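The source may report more compounds than this note shows. Statements on the series, on what has been measured and on what is new or still open speak of the compounds shown alone.

Measured so far:
- compound 1, `CS/C(=N\C(=O)c1ccno1)NC(=O)c1ccno1`: > 100000 nM
- compound 2, `CS/C(=N\C(=O)c1ccco1)NC(=O)c1ccco1`: > 100000 nM
- compound 3, `O=C(/N=C(/NC(=O)c1ccno1)[Se]Cc1ccccc1)c1ccno1`: 94700 nM

All three were tested in a functional assay on K562 cells (Homo sapiens) for cytotoxicity, read by MTT assay, with a stated time of 72 h; a lower number here means that less compound is tolerated, a higher number that more compound is tolerated. For compound 1 the reading is only a limit of this assay and not a number, > 100000 nM. For compound 2 the reading is likewise only a limit, > 100000 nM. Compound 3 gives a number, 94700 nM.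

Compound 1 and compound 3 differ in one place: a group of 8 heavy atoms (7 carbon, 1 selenium; one six-membered aromatic ring of carbon only) in place of a group of 2 heavy atoms (1 carbon, 1 sulfur; no ring), on a carbon with a double bond to nitrogen. The step that this change made is an at least 1.0-fold lower number from compound 1 to compound 3 (0.02 log units; that floor lies within the scatter), and it can be given only as a floor because the limit of > 100000 nM in this assay, at which 2 of the 3 values shown sit, holds for compound 1. Within the scatter of this assay, then, compound 1 and compound 3 cannot be told apart.

Compound 2 carries a different core from compound 1; the difference between the two cores is not broken down here. Compound 4, `O=C(/N=C(/NC(=O)c1ccco1)[Se]Cc1ccccc1)c1ccco1`, has not yet been measured. It stands to compound 2 as compound 3 stands to compound 1: the change is a group of 8 heavy atoms (7 carbon, 1 selenium; one six-membered aromatic ring of carbon only) in place of a group of 2 heavy atoms (1 carbon, 1 sulfur; no ring), on a carbon with a double bond to nitrogen, at a place described in the same words, so it is the same change on the other core.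

Since the same change left compound 1 and compound 3 within the scatter of each other, compound 4 is expected to stay near compound 2, with an expected step of a number no higher from compound 2 to compound 4 (the limit leaves the size open). The estimate for compound 4 in this assay is 100000 nM, expected to fall between 50000 nM and 200000 nM, and it may well again come back only as a limit.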

Compound 4, concentration lethal to 50% of the cells: 80600 nM
For compound 4 the middle estimate is 1.2-fold (0.09 log units) above the measured one; the measured number falls inside the stated range.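

In this assay, replacing methylsulfanyl with the selenium-bearing group that carries the six-membered aromatic ring gives an at least 1.2-fold lower number from compound 2 to compound 4 (0.09 log units; that floor lies within the scatter), so the step on this second core can be stated only as a floor. Set beside the step on the first core, it gives no sign that the two cores respond differently, but it does not show that they respond alike: the same change on two cores in this assay, an at least 1.0-fold lower number (0.02 log units; that floor lies within the scatter) from compound 1 to compound 3 and an at least 1.2-fold lower number (0.09 log units; that floor lies within the scatter) from compound 2 to compound 4; the limit leaves it open whether they differ. Neither step establishes a real change or its true size, and the change cannot be said to carry over with the same effect, because both starting compounds give only a limit and not a number: the limit of > 100000 nM in this assay, at which 2 of the 4 values shown sit.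

This change alters the atom attached to the carbon and adds the aromatic ring in one move, so the compounds shown do not separate the two, as a benzylsulfanyl group or a methylselanyl group on the same carbon could. Also open is whether another group on that carbon, such as an amine, would give a value in this assay clearly apart from those shown.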